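Adding an amino group to compound 1

The source may hold more compounds than are shown below. What is called first, only, known or untested is meant among the compounds shown, and "the series" means these compounds.

- Compound 1 `COc1ncnc2c1c(-c1cc3ccccc3o1)cn2[C@@H]1O[C@H](CO)[C@@H](O)[C@H]1O` gives 10800 nM
- Compound 2 `CN(C)c1ncnc2c1c(-c1cc3ccccc3o1)cn2[C@@H]1O[C@H](CO)[C@@H](O)[C@H]1O` gives > 20000 nM (a limit)

Within the data shown here, in a functional assay on CEM-DNR-bulk cells (Homo sapiens), read by MTT assay, with a stated time of 72 h (on this read-out lower numbers stand for stronger inhibition and higher numbers for weaker inhibition), compound 1 gives 10800 nM, the only actual number so far. Compound 2 stands at > 20000 nM, which is a limit of the assay. Compound 3 `COc1nc(N)nc2c1c(-c1cc3ccccc3o1)cn2[C@@H]1O[C@H](CO)[C@@H](O)[C@H]1O` differs from compound 1 by amino in place of hydrogen on an aromatic carbon, between two ring nitrogen atoms. Among the measured compounds shown here, the one measured step, an at least 1.8-fold higher number from compound 1 to compound 2 (0.26 log units; that floor lies within the scatter), changes a different group, so it offers only weak guidance. The expected step, a 1.1-fold higher number from compound 1 to compound 3 (0.05 log units; within the scatter), is therefore none beyond the scatter. Compound 3 is estimated at 12000 nM, within an expected range of 4000 nM to 30000 nM.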

Compound 3, half-maximal inhibitory concentration: 16700 nM
Beside the measured number, compound 3's estimate is 1.4-fold (0.14 log units) below it; the measured number falls inside the stated range.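

Placed on the aromatic carbon between two ring nitrogen atoms, the amino group gives a 1.5-fold higher number from compound 1 to compound 3 (0.19 log units; within the scatter) in this assay. This position therefore takes an amino group with no change that can be told from the scatter, something the step at the methoxy carbon could not show. Compound 2 remains a limit, not a number, so it cannot be set in order against compound 3: the limit of > 20000 nM in this assay, at which 1 of the 3 values shown sits.

As far as these compounds go, what a chlorine atom or an ethylamino group would do at this position stays open. So does whether the amino group would act the same way on compound 2.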